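Swapping a dichlorophenyl for a cyanophenyl

This account rests on a few compounds, and the source may have more. Where it says the series, first, only, none or still open, it means among the compounds named here.

Three measured compounds share one core and differ only in the aromatic group carried on a saturated chain carbon bound to an amine nitrogen. In a functional assay (Homo sapiens) for inhibition, read by luminescence, with a stated time of 72 h (a lower number here means a stronger inhibitor, a higher number a weaker inhibitor), compound 1 `CSc1nccc(N2CCC(N(C)Cc3c(F)cccc3Cl)CC2)n1` gives 940 nM. Compound 2 `CSc1nccc(N2CCC(N(C)Cc3c(Cl)cccc3Cl)CC2)n1` gives 700 nM, and compound 3 `CSc1nccc(N2CCC(N(C)Cc3ccc(Cl)cc3Cl)CC2)n1` gives 1680 nM. Compound 3 has the highest of the three numbers: the step of a 2.4-fold higher number from compound 2 to compound 3 (0.38 log units; beyond the scatter) is modest, while a 1.8-fold higher number from compound 1 to compound 3 (0.25 log units; within the scatter) and a 1.3-fold lower number from compound 1 to compound 2 (0.13 log units; within the scatter) both stay within the scatter.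

Compound 4 `CSc1nccc(N2CCC(N(C)Cc3ccc(C#N)cc3)CC2)n1` is not yet measured. It differs from compound 3 in one place: 4-cyanophenyl in place of 2,4-dichlorophenyl on a saturated chain carbon bound to an amine nitrogen. Among the compounds with values here, none of the measured steps bears directly on this change; each of them exchanges one halogen-bearing phenyl for another, and none introduces a nitrile or removes both chlorines. The largest step seen, a 2.4-fold higher number from compound 2 to compound 3 (0.38 log units; beyond the scatter), shows that the aromatic group matters, but the direction for a nitrile cannot be read from these data. Compound 4 is therefore expected to give 2200 nM in this assay, with a wide range from 600 nM to 8000 nM. That estimate amounts to an expected step of a 1.3-fold higher number from compound 3 to compound 4 (0.12 log units; within the scatter).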

Compound 4, half-maximal inhibitory concentration: 1470 nM
For compound 4 the middle estimate is 1.5-fold (0.18 log units) above the measured one, and the stated range covers the measured number.
By their numbers in this assay, from the lowest: compounds 2, 1, 4 and 3 (each within the scatter of the next, the first and the last beyond it).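

In this assay, the aromatic group at this position can give up both chlorines and carry a nitrile instead, and the number stays within the scatter, with a 1.1-fold lower number from compound 3 to compound 4 (0.06 log units; within the scatter). So among these compounds, chlorine on the phenyl ring is not needed for a number of this size, and the nitrile also stays within the scatter of the chloro-fluoro group, with a 1.6-fold higher number from compound 1 to compound 4 (0.19 log units; within the scatter), whereas a 2.1-fold higher number from compound 2 to compound 4 (0.32 log units; beyond the scatter) is a modest step beyond the scatter. Nothing shown here gives a measured reason for these numbers.

Still open, going by these compounds, is how a plain phenyl, or a phenyl carrying an amine or a carboxylic acid in place of the nitrile, would read in this assay. A longer chain between the aromatic ring and the amine nitrogen is also untested by these compounds.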